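The compounds below may be only part of what the source reports. "The series", "measured", "known", "first", "only" and "open" are said of these compounds alone.

In an ADME assay on a cell-free system (plasma, Mus musculus) for protein binding, read by LC-MS, using ultracentrifugation, with a stated time of 4.2 h, tested at 1000 ng/mL, the measured compounds stand as follows:
- compound 1 `C=CCOc1ccc(F)c(C(=O)NNS(=O)(=O)c2ccccc2)c1` gives 98%
- compound 2 `Cc1cc(OC(C)C)cc(C(=O)NNS(=O)(=O)c2ccccc2F)c1` gives 98.9%

Compound 2 lies within the scatter of compound 1, so neither stands apart on this read-out. For the measured compounds named here, no two measured compounds differ in one place only, so no single change has been measured directly.

Compound 3 `CCOc1cc(C)cc(C(=O)NNS(=O)(=O)c2ccccc2F)c1` carries ethoxy in place of the isopropoxy of compound 2, the counted difference being hydrogen in place of methyl on a saturated chain carbon bound to an oxygen on an aromatic ring and a saturated chain carbon on a saturated chain carbon bound to an oxygen on an aromatic ring and a saturated chain carbon. Compound 1 and compound 2 stay within the scatter of each other although their structures differ in more than one place, so only a small shift seems likely for this single change. The estimated step a 1.5-fold higher unbound fraction from compound 2 to compound 3 (0.16 log units; within the scatter) is expected to stay within the scatter in this assay and, if it shows at all, to leave slightly more compound free. Compound 3 is expected at 98.4% with 97% to 99.2% as the estimated range.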

Compound 3, plasma protein binding in the Mus musculus assay: 99.6%
Estimate against measurement, compound 3: 4.0-fold (0.60 log units) (unbound fraction) above, outside the stated range (above it).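

For the compounds shown here, in the Mus musculus assay compound 2 gives 98.9% and compound 3 gives 99.6%, and the change from isopropoxy to ethoxy gives a 2.8-fold lower unbound fraction from compound 2 to compound 3 (0.44 log units; beyond the scatter) and is the only single change that can be read directly. It shows that this chain on the oxygen is not silent for plasma protein binding, even when only one methyl goes. In a physicochemical assay for solubility, read by nephelometry, in phosphate buffer, measured as kinetic solubility, at pH 6.5 (on this read-out higher numbers stand for higher solubility and lower numbers for lower solubility), compound 2 gives 12.5 ug/mL and compound 3 gives 12.5 ug/mL, and the same change gives no change at the digits printed from compound 2 to compound 3 (within the scatter), so the two read-outs do not move together for this pair, and nothing at hand accounts for the shift in binding.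

Still open, on these data alone, is whether the trend continues to methoxy or reverses with a longer chain such as butoxy, and what a chain ending in an amine or a carboxylic acid would do. One pair also cannot show whether the same change acts alike where the rest of the structure differs, as it does in compound 1.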